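Nitro for Methyl at the Benzyloxy Terminus

The compounds below may be only part of what the source reports. "The series", "measured", "known", "first", "only" and "open" are said of these compounds alone.

Compound 1, `COc1cccc(OC)c1OCCNCCOc1ccccc1OCc1cccc(Cl)c1`, gives 7.93 in a functional assay on spleen for antagonist activity at Alpha-1B adrenergic receptor (Rattus norvegicus); on this read-out lower numbers stand for lower potency and higher numbers for higher potency (the scale is a negative logarithm).
Compound 2, `COc1cccc(OC)c1OCCNCCOc1ccccc1OCc1ccc(Cl)cc1`, gives 8.06 in this assay.
Compound 3, `COc1cccc(OC)c1OCCNCCOc1ccccc1OCc1ccc(C)cc1`, gives 8.43 in this assay.

Compound 3 stands highest of the three numbers, set apart from both others beyond the scatter: a number 0.50 log units higher from compound 1 to compound 3 (beyond the scatter) and a number 0.37 log units higher from compound 2 to compound 3 (beyond the scatter), whereas a number 0.13 log units higher from compound 1 to compound 2 (within the scatter). Compound 4, `COc1cccc(OC)c1OCCNCCOc1ccccc1OCc1ccc([N+](=O)[O-])cc1`, has not yet been measured in this assay. It differs from compound 3 in one place: nitro in place of methyl on an aromatic carbon. Within the data shown here, the step that bears most directly on it is the exchange at the same aromatic carbon, a number 0.37 log units higher from compound 2 to compound 3 (beyond the scatter), which was modest; no measured step involves nitro itself, so the direction rests only on the observation that the methyl compound gave the highest number. Compound 4 is therefore expected to fall somewhat below compound 3, an estimated step of a number 0.43 log units lower from compound 3 to compound 4 (beyond the scatter) in this assay. Compound 4 is estimated at 8, within a range of 7.5 to 8.5.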

Compound 4, negative logarithm of the antagonist equilibrium constant: 9.02
Estimate against measurement, compound 4: 1.02 log units below, and the stated range ends below it.
By their numbers in this assay, from the lowest: compounds 1 and 2 (each within the scatter of the next); then compound 3; then compound 4.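

In this assay, the carbon para to a large group tolerates more than the methyl of compound 3 suggested: nitro stands clearly above both methyl (a number 0.59 log units higher from compound 3 to compound 4 (beyond the scatter)) and chloro (a number 0.96 log units higher from compound 2 to compound 4 (beyond the scatter)), so the order at this carbon runs chloro, methyl, nitro. Among these compounds, the change from 3-chlorophenyl to 4-nitrophenyl (a number 1.09 log units higher from compound 1 to compound 4 (beyond the scatter)) is the only step in the set that counts as large, and it makes compound 4 the most potent of the four. Nothing available explains why nitro gives the higher number.

Going by these compounds, it remains open whether this gain is particular to nitro or would extend to other groups on the same carbon, such as a nitrile, a trifluoromethyl, a carboxylic acid or an amine. The compounds shown also leave open whether the rise would survive a longer chain in place of the benzyl link.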